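The source may hold more compounds than are shown below. What is called first, only, known or untested is meant among the compounds shown, and "the series" means these compounds.

In an ADME assay on HS27 cells (Homo sapiens) for cytotoxicity, read by MTT assay (on this read-out higher numbers stand for weaker inhibition and lower numbers for stronger inhibition), compound 2 (`COC(=O)c1ccc2c(ccn2-c2ccc(NC(=O)Nc3ccc(Cl)c(C(F)(F)F)c3)cc2)n1`) gives 8200 nM, the higher of the two plain numbers measured here. Compound 1 (`O=C(Nc1ccc(-n2ccc3nc(C(=O)NCc4ccccc4)ccc32)cc1)Nc1ccc(Cl)c(C(F)(F)F)c1`) gives 3000 nM, and the step of a 2.7-fold higher number from compound 1 to compound 2 (0.44 log units; beyond the scatter) separates the two. Compound 3 (`NC(=O)c1ccc2c(ccn2-c2ccc(NC(=O)c3cccc(C(F)(F)F)c3)cc2)n1`) reaches only a limit of this assay, > 10000 nM; this is the line (the limit of > 10000 nM in this assay, at which 1 of the 3 values shown sits). Compound 4 (`COC(=O)c1ccc2c(ccn2-c2ccc(NC(=O)Nc3cccc(Cl)c3Cl)cc2)n1`) differs from compound 2 by 2,3-dichlorophenyl in place of 4-chloro-3-(trifluoromethyl)phenyl on an amide-type nitrogen. Among the compounds with values here, the single measured step concerns a different part of the molecule, so no measured step bears directly on this change. With no evidence for a shift in either direction, compound 4 is expected to show no step beyond the scatter, a 1.0-fold lower number from compound 2 to compound 4 (0.01 log units; within the scatter). Compound 4 is therefore estimated at 8000 nM, in the range 3000 nM to 20000 nM.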

Compound 4, half-maximal inhibitory concentration: > 10000 nM
Compound 4 ended at the assay's limit (the forecaster's own chance of this, stated with the estimate: 35%); at least 1.2-fold (0.09 log units) between middle value and limit.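

Within the data shown here, compound 4 gives the first reading for a change on the aromatic group at the amide-type nitrogen, and in this assay 2,3-dichlorophenyl brings no drop in the number: the step is an at least 1.2-fold higher number from compound 2 to compound 4 (0.08 log units; that floor lies within the scatter). The result for compound 4 is a limit of the assay, not a number, and it adds a second compound at that limit: the limit of > 10000 nM in this assay, at which 2 of the 4 values shown sit.

From the compounds shown here alone, whether this change truly raises the number beyond the scatter stays open. Also open, going by these compounds, is how a plain phenyl or a cyclohexyl group would read on that nitrogen.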